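This account rests on a few compounds, and the source may have more. Where it says the series, first, only, none or still open, it means among the compounds named here.

Series notes. The shared core carries an amine nitrogen whose substituent is varied. Compound 1 `C/C(=C/CN(C[C@H]1Cc2ccccc2CN1)[C@H]1CCCc2cccnc21)CN` gives 8.6 nM in a functional assay on CCRF-CEM cells for antagonist activity at C-X-C chemokine receptor type 4 (Homo sapiens), read by calcium flux, with stated times of 25 min and 90 s; a higher number here means a weaker inhibitor, a lower number a stronger inhibitor. Compound 2 `NC[C@H]1CC[C@H](CN(C[C@H]2Cc3ccccc3CN2)[C@H]2CCCc3cccnc32)CC1` gives 340 nM in this assay, and compound 3 `NCC1=C(CN(C[C@H]2Cc3ccccc3CN2)[C@H]2CCCc3cccnc32)CCCC1` gives 230 nM. Compound 3 stands second highest of the three numbers: a 27-fold higher number from compound 1 to compound 3 (1.43 log units; beyond the scatter) sets it far from compound 1, while a 1.5-fold lower number from compound 2 to compound 3 (0.17 log units; within the scatter) leaves it together with compound 2. Among the measured compounds shown here, the steps that bear on the region altered here are a 40-fold higher number from compound 1 to compound 2 (1.60 log units; beyond the scatter) and a 27-fold higher number from compound 1 to compound 3 (1.43 log units; beyond the scatter), both large and both toward weaker inhibition once a ring enters on the saturated chain carbon bound to the amine nitrogen.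

Compound 4 `N[C@H]1CC[C@H](N(C[C@H]2Cc3ccccc3CN2)[C@H]2CCCc3cccnc32)CC1` is not yet measured. The change: 4-aminocyclohexyl in place of (2-(aminomethyl)cyclohex-1-en-1-yl)methyl on an amine nitrogen. For the measured compounds named here, no measured step covers a ring placed directly on the amine nitrogen; the available steps concern only the presence of a ring-bearing group, under which compound 2 and compound 3 give close numbers. The expectation is therefore that compound 4 stays near the ring-bearing pair, with a step of a 1.7-fold higher number from compound 3 to compound 4 (0.24 log units; within the scatter) not beyond the scatter, though the lack of a precedent for this change widens the range. Compound 4 is estimated at 400 nM in this assay, with a range of 100 nM to 1600 nM.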

Compound 4, half-maximal inhibitory concentration: 34 nM
Compound 4: middle estimate off by 12-fold (1.07 log units), on the high side, outside the stated range (below it).
By their numbers in this assay, from the lowest: compound 1; then compound 4; then compounds 3 and 2 (each within the scatter of the next).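

Among the compounds shown here, compound 4 breaks the link the earlier compounds suggested between a six-membered carbon ring in the substituent and weak inhibition: in this assay, 4-aminocyclohexyl on the amine nitrogen gives a 6.8-fold lower number from compound 3 to compound 4 (0.83 log units; beyond the scatter) and a 10-fold lower number from compound 2 to compound 4 (1.00 log units; beyond the scatter). A ring at this position is therefore compatible with much of the activity of the open-chain group, although a gap to that group remains, with a 4.0-fold higher number from compound 1 to compound 4 (0.60 log units; beyond the scatter). No measurement given here accounts for these differences.

The step to compound 4 changes two features together, since the methyl between the ring and the amine nitrogen and the methyl between the ring and the terminal amine both go, so the compounds shown do not separate the contribution of either. A 4-(aminomethyl)cyclohexyl group or a (4-aminocyclohexyl)methyl group on the same amine nitrogen would address that question, while a piperidin-4-yl group would test whether the amine must stand outside the ring.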